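From 1-(pyridin-4-yl)ethyl to 2-fluorobenzyl on the amide

This account rests on a few compounds, and the source may have more. Where it says the series, first, only, none or still open, it means among the compounds named here.

In an ADME assay on MT4 cells (Homo sapiens) for cytotoxicity, read by MTT assay (a higher number here means that more compound is tolerated, a lower number that less compound is tolerated), compound 1 (`Cc1cc(C)cc(S(=O)(=O)c2c(C(=O)NCC(=O)NCc3ccncc3)[nH]c3ccc(Cl)cc23)c1`) gives > 48900 nM as its reading, which is a limit of the assay and not a number. Among the compounds with values here, compound 2 (`Cc1cc(C)cc(S(=O)(=O)c2c(C(=O)NCC(=O)NC(C)c3ccncc3)[nH]c3ccc(Cl)cc23)c1`) gives 47000 nM as the only true number so far. Within the data shown here, the sole measured step, an at least 1.0-fold lower number from compound 1 to compound 2 (0.01 log units; that floor lies within the scatter) for methyl in place of hydrogen on the chain carbon, is the only guide available. Compound 3 (`Cc1cc(C)cc(S(=O)(=O)c2c(C(=O)NCC(=O)NCc3ccccc3F)[nH]c3ccc(Cl)cc23)c1`) departs further from compound 2, with 2-fluorobenzyl in place of 1-(pyridin-4-yl)ethyl on an amide-type nitrogen as the counted difference: 2-fluorobenzyl in place of 1-(pyridin-4-yl)ethyl on an amide-type nitrogen. Among the measured compounds shown here, no measured step covers that exchange, so the guide is a weak one. The expected step in this assay is a 1.5-fold lower number from compound 2 to compound 3 (0.17 log units; within the scatter) and so none beyond the scatter, with a slightly lower number the likelier direction. Compound 3 is estimated at 32000 nM with an expected range from 10000 nM to 60000 nM in this reading.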

Compound 3, half-maximal cytotoxic concentration: > 47300 nM
Compound 3: no number, only a limit (the forecaster's own chance of this, stated with the estimate: 40%); at least 1.4-fold (0.16 log units) between middle value and limit.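

In this assay, 2-fluorobenzyl in place of 1-(pyridin-4-yl)ethyl on an amide-type nitrogen, which swaps a ring with one hetero atom for a ring of carbon only, gives a number no lower from compound 2 to compound 3 (the limit leaves the size open). The reading of compound 3 is a limit of the assay and not a number: the limit of > 47300 nM in this assay, at which 1 of the 3 values shown sits.

So this position has now carried both ring types with no lower number in this assay, though the step between compound 1 and compound 3 cannot be read, as both readings are limits. The compounds shown leave open how far the true value of compound 3 lies past its limit. They also leave open whether an amine, a carboxylic acid or a longer chain on this amide-type nitrogen would bring the number down.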